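This account rests on a few compounds, and the source may have more. Where it says the series, first, only, none or still open, it means among the compounds named here.

Compound 1 `CCN(CC)CCN(C)c1ccc(Cn2c(=O)[nH]c3c(N)nc(C(F)(F)F)cc32)cn1` is the starting point. Among the measured compounds shown here, in an in vitro ADME assay on microsomes from liver (Homo sapiens) for pharmacokinetics (a lower number here means slower removal, a higher number faster removal of the compound), compound 1 gives 24 mL.min-1.g-1, the higher of the two numbers measured so far. Compound 2 `Nc1nc(C(F)(F)F)cc2c1[nH]c(=O)n2Cc1ccc(NCCN2CCCC2)nc1` gives 8.5 mL.min-1.g-1 in this assay. The measured step of a 2.8-fold lower number from compound 1 to compound 2 (0.45 log units; beyond the scatter) came with a change in which the group entering carried one hydrogen-bond donor and a non-aromatic ring in place of an open chain without a donor. Compound 3 `Nc1nc(C(F)(F)F)cc2c1[nH]c(=O)n2Cc1ccc(NCCN2CCCCC2)nc1` is not yet measured. It differs from compound 1 by (2-(piperidin-1-yl)ethyl)amino in place of (2-(diethylamino)ethyl)(methyl)amino on an aromatic carbon, and the entering group again brings one hydrogen-bond donor and one non-aromatic ring, as the entering group in compound 2 did. For the measured compounds named here, that single step is the only guide, so a step of similar size, downward, is expected in this assay. Compound 3 is therefore expected to give 10 mL.min-1.g-1, within a range from 5 mL.min-1.g-1 to 20 mL.min-1.g-1, an expected step of a 2.4-fold lower number from compound 1 to compound 3 (0.38 log units; beyond the scatter).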

Compound 3, intrinsic clearance in microsomes in the Homo sapiens assay: 13 mL.min-1.g-1
Estimate against measurement, compound 3: 1.3-fold (0.11 log units) below; the measured number falls inside the stated range.
By their numbers in the Homo sapiens assay, from the lowest: compounds 2, 3 and 1 (each within the scatter of the next, the first and the last beyond it).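

The piperidine-bearing chain of compound 3 cannot be told apart from the open chain of compound 1 in the Homo sapiens assay (a 1.8-fold lower number from compound 1 to compound 3 (0.27 log units; within the scatter)), so the clear step seen for compound 2 does not carry over to this second ring-bearing chain. In the same assay, the Homo sapiens assay, exchanging pyrrolidin-1-yl for piperidin-1-yl on the chain also stays within the scatter (a 1.5-fold higher number from compound 2 to compound 3 (0.18 log units; within the scatter)), so these two ring sizes are not separated here. In a physicochemical assay for lipophilicity (on this read-out higher numbers stand for higher lipophilicity and lower numbers for lower lipophilicity), compound 1 gives 1.3 and compound 3 gives 1.3, and nothing available explains either result.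

These compounds change the ring and the hydrogen-bond donor together, so their separate contributions remain unresolved. A (2-(diethylamino)ethyl)amino group would keep the open chain with the donor, while morpholin-4-yl would test a different ring.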